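The source may report more compounds than this note shows. Statements on the series, on what has been measured and on what is new or still open speak of the compounds shown alone.

Three compounds from this study were measured in a functional assay (Cavia porcellus) with sulfonylurea receptors; K-ATP channels (Homo sapiens) as the target; a higher number here means a weaker inhibitor, a lower number a stronger inhibitor. Compound 1 `CC(O)(C(=O)Nc1ccc(C(=O)c2ccccc2)cc1F)C(F)(F)F` gives 11000 nM. Compound 2 `CC(O)(C(=O)Nc1ccc(C(=O)c2ccccc2)c(F)c1)C(F)(F)F` gives 2700 nM, the lowest of the three numbers. Compound 3 `CC(O)(C(=O)Nc1ccc(C(=O)c2ccccc2)cc1O)C(F)(F)F` gives 15000 nM. The difference between the core of compound 1 and the core of compound 2 is not broken down here. Within the shared core of compound 1 and compound 3 the change is hydroxy in place of fluoro on an aromatic carbon, and it produced a 1.4-fold higher number from compound 1 to compound 3 (0.13 log units; within the scatter).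

The unmeasured compound 4 `CC(O)(C(=O)Nc1ccc(C(=O)c2ccccc2)c(O)c1)C(F)(F)F` carries the same kind of change relative to compound 2, namely (hydroxy in place of fluoro on an aromatic carbon); here the group sits ortho to a benzoyl group and meta to a large group, whereas in compound 3 it sits ortho to a large group and meta to a benzoyl group. Because the step of a 1.4-fold higher number from compound 1 to compound 3 (0.13 log units; within the scatter) stayed within the scatter, the step from compound 2 to compound 4 in this assay is expected to be small as well, about a 1.5-fold higher number from compound 2 to compound 4 (0.17 log units; within the scatter), with added uncertainty from the different placement. Compound 4 is therefore estimated at 4000 nM, likely between 1500 nM and 12000 nM.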

Compound 4, half-maximal inhibitory concentration: 4200 nM
Beside the measured number, compound 4's estimate is 1.1-fold (0.02 log units) below it; the measured number falls inside the stated range.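

In this assay, hydroxy in place of fluoro on an aromatic carbon again made only a small step on the second core, a 1.6-fold higher number from compound 2 to compound 4 (0.19 log units; within the scatter), and the two cores can be set side by side: the same change on two cores in this assay, a 1.4-fold higher number (0.13 log units; within the scatter) from compound 1 to compound 3 and a 1.6-fold higher number (0.19 log units; within the scatter) from compound 2 to compound 4, 1.1-fold (0.06 log units) apart, within the scatter of two such steps. Within these two cores, then, the change carried over at a similar small size, although in compound 4 the hydroxy sits ortho to a benzoyl group and meta to a large group, a different placement from that in compound 3. Going by these compounds alone, this rests on only two steps, both within the scatter, so it shows no general rule for the series and gives no reason why the step stays small.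

The compounds shown leave open whether other groups on these aromatic carbons, such as an amine, a methoxy group or a nitrile, would stay as close to fluoro. They also leave open whether the same change would carry over to a core in which a carboxylic acid or a methyl group takes the place of the benzoyl group.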